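Methyl for trifluoromethyl on the anilide ring

The compounds below may be only part of what the source reports. "The series", "measured", "known", "first", "only" and "open" are said of these compounds alone.

Measured so far:
compound 1 `COc1ccc(C(F)(F)F)cc1NC(=O)CN1CCN(S(=O)(=O)N2CCC(C)CC2)CC1`: 2400 nM
compound 2 `COc1ccc(Cl)cc1NC(=O)[C@@H](C)N1CCN(S(=O)(=O)N2CCC(C(F)(F)F)CC2)CC1`: 3500 nM

In an assay on HEK293 cells for inhibition of potassium channel subfamily T member 1 (Homo sapiens), read by thallium flux (on this read-out lower numbers stand for stronger inhibition and higher numbers for weaker inhibition), compound 1 gives 2400 nM and compound 2 gives 3500 nM; the two numbers lie within the scatter of each other, so neither compound is set apart. Compound 3 `COc1ccc(C)cc1NC(=O)CN1CCN(S(=O)(=O)N2CCC(C)CC2)CC1` has not been measured. It differs from compound 1 in one place: methyl in place of trifluoromethyl on an aromatic carbon. Among the compounds with values here, no measured pair shows this change, so no step size is known. The expectation is for a small step, if any, toward weaker inhibition, estimated as a 1.5-fold higher number from compound 1 to compound 3 (0.16 log units; within the scatter). Compound 3 is expected to give about 3500 nM, in the range 1200 nM to 10000 nM.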

Compound 3, half-maximal inhibitory concentration: > 10000 nM
Compound 3: no number, only a limit; the forecaster's own chance of this, stated with the estimate: 10%; middle value at least 2.8-fold (0.45 log units) away from the limit.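

In this assay compound 3 gives > 10000 nM, which is a limit of the assay and not a number. Within the data shown here, this is the first measured change at this position, para to a methoxy group, and methyl does not stand in for trifluoromethyl here: the change gives an at least 4.1-fold higher number from compound 1 to compound 3 (0.61 log units; beyond the scatter). The full size of this step stays unknown, with the reading stopped at the assay limit: the limit of > 10000 nM in this assay, at which 1 of the 3 values shown sits.

On these data alone, what remains open is how a nitrile, a bromine or an ethyl group would read at this position. As far as these compounds go, it is also open whether the step would keep its size on a core carrying a different group on the piperidine.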